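A few compounds are considered here, and "the series" means these few. Any claim that something is new, unique, unknown or untested is made for them only; others in the source may bear on it.

Compounds measured so far:
Compound 1 `Cn1c(-c2ccc(NC(=O)CN3CCN(c4ccccc4)CC3)cc2)nc(-c2ccccc2)c1-c1ccccc1` in a functional assay on MCF7 cells (Homo sapiens) for cytotoxicity, read by MTT assay, with a stated time of 24 h, tested at 80 ug/mL; on this read-out higher numbers stand for a stronger effect at the one concentration tested and lower numbers for a weaker effect: 72.5%
Compound 2 `Cc1ccc(CN2CCN(CC(=O)Nc3ccc(-c4nc(-c5ccccc5)c(-c5ccccc5)n4C)cc3)CC2)cc1` in this assay: 49.3%

Within the data shown here, compound 2 stands lowest of the two numbers; the one step, a number 23.2 percentage points lower from compound 1 to compound 2 (beyond the scatter), separates it from compound 1, which gives the higher number. Compound 3 `COc1ccc(CN2CCN(CC(=O)Nc3ccc(-c4nc(-c5ccccc5)c(-c5ccccc5)n4C)cc3)CC2)cc1` has not yet been measured in this assay. It differs from compound 2 in one place: methoxy in place of methyl on an aromatic carbon. Among the measured compounds shown here, no measured step bears directly on this change; the only step known, a number 23.2 percentage points lower from compound 1 to compound 2 (beyond the scatter), concerns the exchange of phenyl for 4-methylbenzyl on the amine nitrogen in a ring and says nothing about what follows from methoxy in place of methyl on that benzyl. In the absence of a comparable pair, the expected step in this assay from compound 2 to compound 3 is none beyond the scatter, which the estimate expresses as a number 0.7 percentage points higher from compound 2 to compound 3 (within the scatter). Compound 3 is therefore estimated at 50%, within a range of 35% to 65%.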

Compound 3, a percentage reported as activity, at one concentration (the size of the read-out at that concentration, not a potency): 34.5%
Compound 3: middle estimate off by 15.5 percentage points, on the high side, and the stated range ends above it.
By their numbers in this assay, from the lowest: compound 3; then compound 2; then compound 1.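

Methoxy in place of methyl on the aromatic carbon of the benzyl group gives a number 14.8 percentage points lower from compound 2 to compound 3 (beyond the scatter) in this assay, so this read-out responds to the group at this position and not only to the exchange of phenyl on the amine nitrogen. Against the phenyl compound, 4-methoxybenzyl gives a number 38 percentage points lower from compound 1 to compound 3 (beyond the scatter), which puts compound 3 lowest of the three and shows that the result of replacing phenyl depends on the group the benzyl carries. No measurement at hand accounts for this difference between methyl and methoxy.

Among these compounds, only two groups at this position can be compared, so the compounds leave open how an unsubstituted benzyl, a chlorine atom, a hydroxyl or an amine there would read. Also open, as far as these compounds go, is whether a longer chain between the amine nitrogen and the aromatic ring would keep these differences.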